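Swapping Trifluoromethyl for Bromo on Compound 1

The source may hold more compounds than are shown below. What is called first, only, known or untested is meant among the compounds shown, and "the series" means these compounds.

Compound 1 `C=C1C(=O)[C@]23C[C@@]1(O)CC[C@H]2c1ccc(O)c(C)c1[C@@H]3Cn1cc(-c2ccc(C(F)(F)F)cc2)nn1` carries a triazole-linked aryl group on the shared core. Among the compounds with values here, in a functional assay on HL-60 cells (Homo sapiens) for cytotoxicity, read by MTT assay, with a stated time of 4 days (a higher number here means a weaker inhibitor, a lower number a stronger inhibitor), compound 1 gives 720 nM, the only definite number among the three compounds measured. Compound 2 `COc1ccc(-c2cn(C[C@H]3c4c(ccc(OS(=O)(=O)c5ccc(C)cc5)c4C)[C@@H]4CC[C@@]5(C)C[C@]43CC5=O)nn2)cc1` reaches only the limit of this assay, > 20000 nM. Compound 3 `C=C1C[C@]23C[C@@]1(O)CC[C@H]2c1cc(Br)c(O)c(C)c1[C@@H]3Cn1cc(-c2ccccc2)nn1` likewise gives only a limit, > 20000 nM. Compound 4 `C=C1C(=O)[C@]23C[C@@]1(O)CC[C@H]2c1ccc(O)c(C)c1[C@@H]3Cn1cc(-c2ccc(Br)cc2)nn1` differs from compound 1 by bromo in place of trifluoromethyl on an aromatic carbon. Within the data shown here, no measured pair isolates this change, so the expectation rests on compound 1 alone. The step is expected to be small, a 1.3-fold higher number from compound 1 to compound 4 (0.10 log units; within the scatter), with no clear direction beyond the usual scatter. Compound 4 is therefore estimated at 900 nM, within 300 nM to 3000 nM.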

Compound 4, half-maximal inhibitory concentration: 560 nM
Beside the measured number, compound 4's estimate is 1.6-fold (0.21 log units) above it, and the stated range covers the measured number.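

In this assay, within the data shown here, this is the first measured pair that isolates a change at this position, and bromo in place of trifluoromethyl gives a 1.3-fold lower number from compound 1 to compound 4 (0.11 log units; within the scatter). On an aromatic carbon para to a large group, a single bromine atom and the four heavy atoms of trifluoromethyl therefore cannot be told apart in this assay. Compound 2 and compound 3 differ from these two in more than one place and give only a limit: the limit of > 20000 nM in this assay, at which 2 of the 4 values shown sit.

Only these two groups can be compared here. From the compounds shown here alone, what an amine or a carboxylic acid at this position would do remains open.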